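Hydroxy to methoxy on the core of compound 1

A few compounds are considered here, and "the series" means these few. Any claim that something is new, unique, unknown or untested is made for them only; others in the source may bear on it.

Measured so far in a functional assay on NCI/ADR-RES cells (Homo sapiens) for cytotoxicity, read by sulforhodamine B assay, with a stated time of 48 h; on this read-out higher numbers stand for weaker inhibition of growth and lower numbers for stronger inhibition of growth:
- compound 1 `COc1cc(C(=O)c2ccc(OC)c(O)c2OC)cc(OC)c1O`: 515 nM
- compound 2 `COc1cc(C(=O)c2ccc3c(c2)oc(=O)n3S(C)(=O)=O)cc(OC)c1OC`: 2030 nM

Compound 1 holds the lower of the two numbers, so it is the stronger inhibitor of growth here, and its gap to compound 2 lies beyond the scatter. The two compounds differ in more than one place, so this gap says nothing about any single change.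

The next compound is compound 3 `COc1ccc(C(=O)c2cc(OC)c(OC)c(OC)c2)c(OC)c1O`. It carries methyl in place of hydrogen on an oxygen on an aromatic ring, which reads as hydroxy to methoxy: methyl in place of hydrogen on an oxygen on an aromatic ring.

Among the measured compounds shown here, no measured pair shows this change, so the expectation rests on the structural change alone and stays wide. In this assay a moderate move to a lower number is expected, although a result within the scatter or a move upward would not be surprising. The estimated step is a 2.6-fold lower number from compound 1 to compound 3 (0.41 log units; beyond the scatter). For compound 3 the expected value is 200 nM, with an estimated range of 40 nM to 900 nM.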

Compound 3, concentration for 50% growth inhibition: < 10 nM
Compound 3: no number, only a limit; the forecaster's own chance of this, stated with the estimate: 3%; middle value at least 20-fold (1.30 log units) away from the limit.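

In this assay, among the compounds shown here, hydroxy to methoxy, with methyl in place of hydrogen on an oxygen on an aromatic ring, gives an at least 51-fold lower number from compound 1 to compound 3 (1.71 log units; beyond the scatter), the first comparison that isolates a single place. It shows that this oxygen is highly sensitive to substitution: the loss of a hydrogen atom and the entry of one carbon are enough for a large step. Compound 3 gives < 10 nM, which is a limit of the assay and not a number, so the step is a bound and its full size cannot be read: the limit of < 10 nM in this assay, at which 1 of the 3 values shown sits.

The compounds shown do not tell whether the step depends on methyl itself or simply on the loss of the hydrogen, nor whether ethoxy, a longer chain on this oxygen, or an amine in place of the hydroxy would stay at the same level. They also leave open what the remaining hydroxy of compound 3 contributes, since no pair shown changes that group alone.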